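Changing the Sulfonyl Substituent of Compound 3

The source may report more compounds than this note shows. Statements on the series, on what has been measured and on what is new or still open speak of the compounds shown alone.

Among the compounds with values here, in a physicochemical assay for solubility, in phosphate buffer, with a stated time of 24 h, at pH 7.4, tested at 100 uM (on this read-out lower numbers stand for lower solubility and higher numbers for higher solubility), compound 1 (`O=C(NCc1ccc(S(=O)(=O)c2ccccc2)cc1)c1cc2cnccc2[nH]1`) gives 3000 nM and compound 2 (`O=C(NCc1ccc(S(=O)(=O)c2ccccc2)cc1)N1CCc2ccncc2C1`) gives 115000 nM as the highest number so far. Compound 3 (`O=C(NCc1ccc(S(=O)(=O)c2cccc(C(F)(F)F)c2)cc1)N1Cc2ccncc2C1`) gives 10000 nM and stands second highest of the three, with its gaps to both others beyond the scatter. Compound 4 (`CC(C)n1cc(S(=O)(=O)c2ccc(CNC(=O)N3Cc4ccncc4C3)cc2)cn1`) carries 1-isopropyl-1H-pyrazol-4-yl in place of 3-(trifluoromethyl)phenyl on a sulfonyl sulfur. Within the data shown here, no measured pair shows this change on its own, so the expectation in this assay is a judgement: a rise beyond the scatter. The expected step is a 4.5-fold higher number from compound 3 to compound 4 (0.65 log units; beyond the scatter). Compound 4 is estimated at 45000 nM within an expected range from 15000 nM to 110000 nM in this measurement.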

Compound 4, solubility: 192000 nM
Compound 4: middle estimate off by 4.3-fold (0.63 log units), on the low side; the measured number lies above the stated range.
By their numbers in this assay, from the lowest: compound 1; then compound 3; then compounds 2 and 4 (each within the scatter of the next).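

In this assay, the number responds strongly to the group on the sulfonyl sulfur, with a 19-fold higher number from compound 3 to compound 4 (1.28 log units; beyond the scatter) when 1-isopropyl-1H-pyrazol-4-yl replaces 3-(trifluoromethyl)phenyl. The earlier compounds shown here differed from one another in more than one place, so none of them isolated this position. No evidence at hand bears on why the step is this large. This single step cannot separate the change of ring from the isopropyl group that enters with it. From the compounds shown here alone, whether an unsubstituted pyrazole, or a phenyl ring bearing an amine, on the sulfonyl sulfur would give a similar number remains open.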